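The source may hold more compounds than are shown below. What is called first, only, known or untested is meant among the compounds shown, and "the series" means these compounds.

Measured compounds:
compound 1, `O=C(Nc1cc(Oc2ccc(Nc3nccc4[nH]cc(-c5ccc(F)cc5)c(=O)c34)cc2F)ccn1)C1CCC1`: 52.8%
compound 2, `CC(=O)Nc1cc(Oc2ccc(Nc3nccc4[nH]cc(-c5ccc(F)cc5)c(=O)c34)cc2F)ccn1`: 77.1%
compound 3, `CCCCC(=O)Nc1cc(Oc2ccc(Nc3nccc4[nH]cc(-c5ccc(F)cc5)c(=O)c34)cc2F)ccn1`: 62.7%

In a functional assay on MKN-45 cells (Homo sapiens) for antiproliferative activity, read by MTT assay, with a stated time of 72 h, tested at 10 uM (a lower number here means less inhibition, a higher number more inhibition at the concentration tested (going by the name of the read-out)), compound 3 stands second highest of the three numbers; compound 1 lies within the scatter of it, while compound 2 lies beyond it. Compound 4, `O=C(CO)Nc1cc(Oc2ccc(Nc3nccc4[nH]cc(-c5ccc(F)cc5)c(=O)c34)cc2F)ccn1`, differs from compound 3 in one place: hydroxy in place of propyl on a saturated chain carbon bound to a carbonyl carbon. Within the data shown here, two measured steps bear on this change. a number 14.4 percentage points lower from compound 2 to compound 3 (beyond the scatter), so at this same place a smaller group went with more inhibition. a number 9.9 percentage points higher from compound 1 to compound 3 (within the scatter), so butyl and cyclobutyl cannot be told apart. Since a hydroxy is a far smaller group than propyl, compound 4 is expected to move back toward compound 2. The expected step is a number 11.3 percentage points higher from compound 3 to compound 4 (beyond the scatter). Compound 4 is therefore estimated at 74%, within a range of 58% to 88%.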

Compound 4, a percentage reported as inhibition, at one concentration (the size of the read-out at that concentration, not a potency): 63%
For compound 4 the middle estimate is 11 percentage points above the measured one; measured number inside the range.
By their numbers in this assay, from the lowest: compounds 1, 3 and 4 (each within the scatter of the next, the first and the last beyond it); then compound 2.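

In this assay, hydroxy and propyl on a saturated chain carbon bound to a carbonyl carbon cannot be told apart (a number 0.3 percentage points higher from compound 3 to compound 4 (within the scatter)). The smaller group alone therefore does not bring the number back to that of compound 2, since hydroxy in place of hydrogen at this carbon still gives a drop (a number 14.1 percentage points lower from compound 2 to compound 4 (beyond the scatter)). Hydroxymethyl in place of cyclobutyl on the carbonyl carbon gives a gain (a number 10.2 percentage points higher from compound 1 to compound 4 (beyond the scatter)). No evidence here explains these differences. The compounds shown leave open how an amine or a carboxylic acid would read at this carbon.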